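Swapping Methyl for Chloro in a Weak Cytotoxic Compound

This account rests on a few compounds, and the source may have more. Where it says the series, first, only, none or still open, it means among the compounds named here.

In a functional assay on KB 3-1 cells (Homo sapiens) for cytotoxicity, read by MTT assay, with a stated time of 68 h (a higher number here means a weaker inhibitor, a lower number a stronger inhibitor), compound 1 `COc1ccc(-c2cc(NC(=O)C(Cl)Cl)cc(-c3ccc(OC)c(F)c3)c2)cc1F` gives 2940 nM while compound 2 `Cc1ccccc1-c1cccc(NC(=O)C(Cl)Cl)c1` gives 42000 nM as the higher number of the two, which makes it clearly the weaker inhibitor of the pair. Compound 3 `O=C(Nc1cccc(-c2ccc(-c3ccccc3)cc2)c1)C(Cl)Cl` gives > 50000 nM as a limit of the assay and not a number. Compound 4 `O=C(Nc1cccc(-c2ccccc2Cl)c1)C(Cl)Cl` is compound 2 with one change chloro in place of methyl on an aromatic carbon that puts chloro in place of methyl on an aromatic carbon, ortho to a large group. For the measured compounds named here, no measured pair shows this swap, so the expectation rests on compound 2 at 42000 nM alone. In this assay the estimated step of a 1.2-fold lower number from compound 2 to compound 4 (0.08 log units; within the scatter) is expected to stay within the usual scatter, with no firm direction. For compound 4 the estimated value is 35000 nM with an expected range from 14000 nM to 50000 nM in repeat measurements.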

Compound 4, half-maximal inhibitory concentration: > 50000 nM
Compound 4 ended at the assay's limit (the forecaster's own chance of this, stated with the estimate: 25%); at least 1.4-fold (0.15 log units) between middle value and limit.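

In this assay chloro in place of methyl on an aromatic carbon, ortho to a large group, gives an at least 1.1-fold higher number from compound 2 to compound 4 (0.07 log units; that floor lies within the scatter) and so no stronger inhibitor at this position. Compound 4 gives > 50000 nM as a limit of the assay and not a number. The full size of the step cannot be read, because the value stops at this limit: the limit of > 50000 nM in this assay, at which 2 of the 4 values shown sit.

As far as these compounds go, whether an amine or a hydroxyl group on this same carbon would give a clearly lower number stays open.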